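From furan-3-yl to 3-fluorophenyl on the shared core

The compounds below may be only part of what the source reports. "The series", "measured", "known", "first", "only" and "open" are said of these compounds alone.

Compound 3 (`Nc1ccc(S(=O)(=O)N2CCN(c3ncc(C(O)(C(F)(F)F)C(F)(F)F)cc3-c3ccoc3)CC2)cn1`) has no exact number in an ADME assay (liver) for metabolic stability, with Liver microsome (Homo sapiens) as the target, using microsomes and NADPH, with a stated time of 30 min, tested at 1 uM; on this read-out lower numbers stand for slow clearance and higher numbers for fast clearance: compound 3 reads < 14 mL.min-1.g-1, which is a limit. Compound 2 (`Nc1ccc(S(=O)(=O)N2CCN(c3ncc(C(O)(C(F)(F)F)C(F)(F)F)cc3C#CC3CC3)CC2)cn1`) likewise reads < 14 mL.min-1.g-1, also a limit. Compound 1 (`Nc1ccc(S(=O)(=O)N2CCN(c3ncc(C(O)(C(F)(F)F)C(F)(F)F)cc3C3CC3)CC2)cn1`) gives 38 mL.min-1.g-1. The measured steps show an at least 2.7-fold lower number from compound 1 to compound 2 (0.43 log units; beyond the scatter) and an at least 2.7-fold lower number from compound 1 to compound 3 (0.43 log units; beyond the scatter), whereas a step that the two limits leave unreadable from compound 2 to compound 3. Compound 4 (`Nc1ccc(S(=O)(=O)N2CCN(c3ncc(C(O)(C(F)(F)F)C(F)(F)F)cc3-c3cccc(F)c3)CC2)cn1`) carries 3-fluorophenyl in place of furan-3-yl on an aromatic carbon. Among the compounds with values here, no measured step makes this exchange, so only the aromatic replacement in an at least 2.7-fold lower number from compound 1 to compound 3 (0.43 log units; beyond the scatter) offers guidance. A small rise, probably near the scatter, is expected, namely an at least 1.2-fold higher number from compound 3 to compound 4 (0.08 log units; that floor lies within the scatter). The estimate for compound 4 is 17 mL.min-1.g-1, within an expected range of 9 mL.min-1.g-1 to 40 mL.min-1.g-1.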

Compound 4, intrinsic clearance in microsomes: 25 mL.min-1.g-1
Compound 4: the middle estimate sits 1.5-fold (0.17 log units) below what was measured, within the range that was stated.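

With 3-fluorophenyl on this aromatic carbon, this assay gives an exact number for an aromatic ring, which furan-3-yl did not, so an aromatic ring here does not by itself bring the read-out down to the limit. The steps show an at least 1.7-fold higher number from compound 3 to compound 4 (0.25 log units; that floor lies within the scatter) and an at least 1.7-fold higher number from compound 2 to compound 4 (0.25 log units; that floor lies within the scatter), and both are floors resting on a limit rather than a number: the limit of < 14 mL.min-1.g-1 in this assay, at which 2 of the 4 values shown sit. Cyclopropyl and 3-fluorophenyl are not told apart, with a 1.5-fold lower number from compound 1 to compound 4 (0.18 log units; within the scatter).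

On these data alone, what the fluorine itself contributes remains open. So does how a plain phenyl or a pyridine ring would read at this position.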